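Swapping an Acetyl for Dimethylamino on a Pyrazole Series

This account rests on a few compounds, and the source may have more. Where it says the series, first, only, none or still open, it means among the compounds named here.

This account follows one pair of closely related compounds from a study of growth inhibition. The series was tested in a functional assay on DU-145 cells (Homo sapiens) for inhibition, read by sulforhodamine B assay, with a stated time of 48 h; on this read-out lower numbers stand for stronger inhibition of growth and higher numbers for weaker inhibition of growth. Compound 1 `COc1cc(C)cc(-c2c(-c3ccnc(-c4ccc(C(C)=O)cc4)c3)cnn2CC#N)c1` gives in this assay only a limit, > 100000 nM, and not a number. Two further members of the series do return numbers: compound 2 `COc1cc(C)cc(-c2nn(CC#N)cc2-c2ccc(-c3cccc(C(C)=O)c3)nc2)c1` gives 4950 nM, and compound 3 `Cc1cc(O)cc(-c2nn(CC#N)cc2-c2ccnc(-c3ccc(Oc4ccccc4)cc3)c2)c1` gives 7180 nM. For the measured compounds named here, the evidence therefore is thin: the limit of > 100000 nM in this assay, at which 1 of the 3 values shown sits, with no measured step between any two compounds that differ in a single place.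

Compound 4 `COc1cc(C)cc(-c2c(-c3ccnc(-c4ccc(N(C)C)cc4)c3)cnn2CC#N)c1` has not yet been measured. It differs from compound 1 by dimethylamino in place of acetyl on an aromatic carbon. Since compound 1 sits at the limit, any number for compound 4 would be a step in the direction of stronger inhibition, and the author expects a step of an at least 2.5-fold lower number from compound 1 to compound 4 (0.39 log units; beyond the scatter) beyond the scatter, though with little confidence. The estimate for compound 4 in this assay is 40000 nM, with a range from 6000 nM to 200000 nM.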

Compound 4, concentration for total growth inhibition: 334 nM
Compound 4: the middle estimate sits 120-fold (2.08 log units) above what was measured; the measured number lies below the stated range.
By their numbers in this assay, from the lowest: compound 4; then compounds 2 and 3 (each within the scatter of the next). At a limit, above all of these: compound 1.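

Replacing 4-acetylphenyl with 4-(dimethylamino)phenyl shows that, in this assay, the group on this aromatic carbon, para to a large group, can alone separate a compound at the limit from one with a measured value, giving an at least 290-fold lower number from compound 1 to compound 4 (2.47 log units; beyond the scatter) for this single change. Compound 1 gives > 100000 nM as a limit of the assay and not a number. The step is therefore a bound, and its full size cannot be read: the limit of > 100000 nM in this assay, at which 1 of the 4 values shown sits.

The compounds shown do not tell whether the difference comes from gaining dimethylamino or from losing acetyl, or how a primary amine or a carboxylic acid would read at this place. They also leave open whether the same change would have a similar effect on compounds with the differently arranged structures of compound 2 and compound 3.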